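The source may report more compounds than this note shows. Statements on the series, on what has been measured and on what is new or still open speak of the compounds shown alone.

Compound 1 `CCCCCCCCCCCC(=O)OC[C@H](CSC[C@@H](N)C(=O)NCCCCCCCCCC(=O)O)OC(=O)CCCCCCCCCCC`: 4400 nM
Compound 2 `CCCCCCCCCCCC(=O)OC[C@H](CSC[C@@H](N)C(=O)NCCCN)OC(=O)CCCCCCCCCCC`: 1960 nM

Among the compounds with values here, in an assay on HEK293 cells for agonist activity at Toll-like receptor 2 (Homo sapiens) (a lower number here means that less compound is needed, a higher number that more compound is needed for the effect), compound 2 gives the lowest of the two numbers; the one measured step, a 2.2-fold lower number from compound 1 to compound 2 (0.35 log units; beyond the scatter), separates it from compound 1. Compound 3 `CCCCCCCCCCCC(=O)OC[C@H](CSC[C@@H](N)C(=O)NCCCn1ccnc1)OC(=O)CCCCCCCCCCC` differs from compound 2 by 1H-imidazol-1-yl in place of amino on a saturated chain carbon, three bonds along the chain from an amide-type nitrogen. Within the data shown here, the step from compound 1 to compound 2 exchanged a different group at this same place, so no measured step speaks directly to swapping amino for an imidazole ring; the change is therefore expected to stay small. Compound 3 is estimated at 2500 nM in this assay, between 800 nM and 8000 nM. The expected step is a 1.3-fold higher number from compound 2 to compound 3 (0.11 log units; within the scatter).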

Compound 3, half-maximal effective concentration: 410 nM
Compound 3: middle estimate off by 6.1-fold (0.79 log units), on the high side; measured number outside the range, below it.
By their numbers in this assay, from the lowest: compound 3; then compound 2; then compound 1.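

At this place, on a saturated chain carbon three bonds along the chain from an amide-type nitrogen, 1H-imidazol-1-yl in place of amino gives a 4.8-fold lower number from compound 2 to compound 3 (0.68 log units; beyond the scatter) in this assay and in place of 6-carboxyhexyl gives an 11-fold lower number from compound 1 to compound 3 (1.03 log units; beyond the scatter) in the same read-out. So this place accepts a five-membered aromatic ring and gains from it, a larger change than the step between the two earlier groups, a 2.2-fold lower number from compound 1 to compound 2 (0.35 log units; beyond the scatter) in size. Nothing measured here explains the gain.

The compounds shown leave open whether the ring's nitrogens matter, which a phenyl group here would test. They also leave open whether a longer chain carrying 1H-imidazol-1-yl keeps the gain.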